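A few compounds are considered here, and "the series" means these few. Any claim that something is new, unique, unknown or untested is made for them only; others in the source may bear on it.

Measured compounds:
- compound 1, `CC(C)(C)c1cn(C[C@H](O)[C@H]2OC(=O)C(OCc3ccccc3)=C2OCc2ccccc2)nn1`, 13300 nM
- compound 2, `COc1ccc(-c2cn(C/C=C3\OC(=O)C(OCc4ccccc4)=C3OCc3ccccc3)nn2)cc1`, > 100000 nM, which is a limit of the assay
- compound 3, `COc1ccccc1-c1cn(C/C=C2\OC(=O)C(OCc3ccccc3)=C2OCc2ccccc2)nn1`, > 100000 nM, which is a limit of the assay

Among the compounds with values here, in an ADME assay on HFF cells (Homo sapiens) for cytotoxicity, read by MTT assay, with a stated time of 72 h (on this read-out lower numbers stand for stronger inhibition and higher numbers for weaker inhibition), compound 1 gives 13300 nM, the only true number among the three values shown. Compound 2 sits at a limit, > 100000 nM. Compound 3 also sits at a limit, > 100000 nM. Within the data shown here, the one step between measured compounds that differ in a single place, a step that the two limits leave unreadable from compound 2 to compound 3, therefore cannot be read, because of the limit of > 100000 nM in this assay, at which 2 of the 3 values shown sit.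

Compound 4, `O=C1O[C@H]([C@@H](O)Cn2cc(C3CC3)nn2)C(OCc2ccccc2)=C1OCc1ccccc1`, is not yet measured. It differs from compound 1 by cyclopropyl in place of tert-butyl on an aromatic carbon. No measured step touches this change: the only step shown concerns a methoxyphenyl group on a different part of the shared core and is itself unreadable. Nothing in the data therefore speaks for a move in either direction, and compound 4 is expected to stay within the usual scatter of compound 1, with an estimated 1.1-fold higher number from compound 1 to compound 4 (0.05 log units; within the scatter). For compound 4 the estimate is 15000 nM, spanning from 5000 nM to 50000 nM, with the possibility that this assay reports only a limit as well.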

Compound 4, half-maximal inhibitory concentration: 24300 nM
Estimate against measurement, compound 4: 1.6-fold (0.21 log units) below; the measured number falls inside the stated range.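

In this assay, cyclopropyl in place of tert-butyl gives a 1.8-fold higher number from compound 1 to compound 4 (0.26 log units; within the scatter). Within the data shown here, this is the first readable step, and it shows that on this aromatic carbon, next to the ring nitrogen of the five-membered aromatic ring, the two carbon-only groups cannot be told apart, even though one brings a three-membered ring and has one heavy atom fewer. Compound 4 also gives a true number rather than a limit, so the series now holds two measured values on the same side chain, whereas the only earlier step, between the two methoxyphenyl compounds, cannot be read because of a limit of the assay: the limit of > 100000 nM in this assay, at which 2 of the 4 values shown sit.

As far as these compounds go, the result covers only these two small carbon-only groups, so it remains open whether an amine, a carboxylic acid or a longer chain such as n-hexyl on this aromatic carbon would move the number beyond the scatter. From the compounds shown here alone, compound 2 and compound 3 differ from compound 1 in more than one place, so the effect of an aryl group at this position on the hydroxyl-bearing side chain also remains open.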